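Replacing 4-fluorophenyl with pyridin-3-yl in compound 2

The source may report more compounds than this note shows. Statements on the series, on what has been measured and on what is new or still open speak of the compounds shown alone.

Compound 1 `CCOC(=O)c1ccc(-c2nn(Cc3cccc(Cl)c3)c3ccccc23)cc1`: > 10000 nM
Compound 2 `CCOC(=O)c1ccc(-c2nn(Cc3ccc(F)cc3)c3ccccc23)cc1`: > 10000 nM

In a functional assay on cells (Platelet, Homo sapiens) for inhibition (a lower number here means a stronger inhibitor, a higher number a weaker inhibitor), compound 2 gives > 10000 nM, which is a limit of the assay and not a number. Compound 1 gives > 10000 nM, also a limit. Compound 3 `CCOC(=O)c1ccc(-c2nn(Cc3cccnc3)c3ccccc23)cc1` differs from compound 2 in one group: pyridin-3-yl in place of 4-fluorophenyl on a saturated chain carbon bound to an aromatic nitrogen. Among the compounds with values here, the only measured step, a step that the two limits leave unreadable from compound 1 to compound 2, offers no size to build on. Compound 1 and compound 2 share one limit, (the limit of > 10000 nM in this assay, at which 2 of the 2 values shown sit), so compound 3 is expected to stay close to it in this assay, with no clear direction. The expected change is a step that the limit leaves unreadable from compound 2 to compound 3. For compound 3 the estimate is 15000 nM. The estimated range for compound 3 runs from 4000 nM to 50000 nM.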

Compound 3, half-maximal inhibitory concentration: > 10000 nM
Compound 3 was reported as a limit (the forecaster's own chance of this, stated with the estimate: 75%); the middle value is on the limit's open side.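

No step can be read among compound 1, compound 2 and compound 3 in this assay, as each result is a limit and not a number: the limit of > 10000 nM in this assay, at which 3 of the 3 values shown sit.

On these data alone, how 3-chlorophenyl, 4-fluorophenyl and pyridin-3-yl rank against one another stays open.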